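Furan-3-yl in place of cyclopentyl at the saturated ring carbon

A few compounds are considered here, and "the series" means these few. Any claim that something is new, unique, unknown or untested is made for them only; others in the source may bear on it.

Compound 1 `CCOC(=O)C1=C(C)N/C(=N\C#N)NC1c1ccco1` and compound 2 `CCOC(=O)C1=C(C)N/C(=N\C#N)NC1C1CCCC1` share one core and differ only in the group on the saturated ring carbon. In an assay on cells for displacement of a labelled ligand from adenosine receptor A1 (Homo sapiens), with a stated time of 60 min, tested at 1 uM (on this read-out higher numbers stand for more inhibition at the one concentration tested (going by the name of the read-out) and lower numbers for less inhibition), compound 1 gives 27%, and compound 2 gives 11%. Among the compounds with values here, compound 2 stands lowest of the two numbers known so far; its nearest neighbour is compound 1, and the step of a number 16 percentage points lower from compound 1 to compound 2 (beyond the scatter) came with cyclopentyl in place of furan-2-yl on a saturated ring carbon.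

Compound 3 `CCOC(=O)C1=C(C)N/C(=N\C#N)NC1c1ccoc1` is not yet measured. It differs from compound 2 as follows: furan-3-yl in place of cyclopentyl on a saturated ring carbon. Within the data shown here, the only step that bears on this change is a number 16 percentage points lower from compound 1 to compound 2 (beyond the scatter), which runs in the reverse sense, from an aromatic five-membered ring bearing one oxygen to the saturated carbon ring. Compound 3 returns to a five-membered aromatic ring with one hetero atom, though attached through a different ring atom than in compound 1, so a partial return toward the number of compound 1 is the working expectation. For compound 3 the estimate in this assay is 22%, within 8% to 38%, meaning an expected step of a number 11 percentage points higher from compound 2 to compound 3 (beyond the scatter).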

Compound 3, a percentage reported as inhibition, at one concentration (the size of the read-out at that concentration, not a potency): 28%
Compound 3: the middle estimate sits 6 percentage points below what was measured; the measured number falls inside the stated range.
By their numbers in this assay, from the lowest: compound 2; then compounds 1 and 3 (each within the scatter of the next).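

In this assay, the change at the saturated ring carbon gives a number 17 percentage points higher from compound 2 to compound 3 (beyond the scatter), so cyclopentyl now stands apart from a second furan and not only from furan-2-yl. The change of attachment within the furan gives a number 1 percentage points higher from compound 1 to compound 3 (within the scatter), so this read-out does not separate furan-3-yl from furan-2-yl at this position, and among these three compounds the split lies between the two furans and cyclopentyl, with no compound going against it. No measurement at hand accounts for that split.

Still open, from the compounds shown here alone, is whether a phenyl or thiophen-2-yl ring, an open chain such as pentyl, or a group carrying an amine on the saturated ring carbon would fall with the furans, with cyclopentyl, or apart from both. Going by these compounds, every number in this assay also comes from a single tested concentration and gives no potency, and the ethoxycarbonyl and methyl groups stay constant throughout, so it remains unknown whether the step between furan and cyclopentyl would persist with an amide in place of the ethoxycarbonyl group.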